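The compounds below may be only part of what the source reports. "The series", "measured", "known", "first", "only" and "open" are said of these compounds alone.

Among the measured compounds shown here, in a functional assay on MCF7 cells (Homo sapiens) for antiproliferative activity, read by CCK-8 assay, with a stated time of 48 h (a higher number here means a weaker inhibitor, a lower number a stronger inhibitor), three compounds built on one shared core have numbers so far. Compound 1 `C=CC(=O)NCCOc1ccc(Oc2c(-c3ccc(F)cc3)sc3cc(O)ccc23)cc1` gives 23000 nM and compound 3 `C=CC(=O)N1CC(Oc2ccc(Oc3c(-c4ccc(F)cc4)sc4cc(O)ccc34)cc2)C1` gives 23500 nM. These two sit level, with a 1.0-fold higher number from compound 1 to compound 3 (0.01 log units; within the scatter). Compound 2 `O=C(/C=C/CN1CC(Oc2ccc(Oc3c(-c4ccc(F)cc4)sc4cc(O)ccc34)cc2)C1)N1CCCC1` gives 8450 nM, and a 2.8-fold higher number from compound 2 to compound 3 (0.44 log units; beyond the scatter) places compound 3 on the weaker side of compound 2.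

Compound 4 `C=C(C)C(=O)N1CC(Oc2ccc(Oc3c(-c4ccc(F)cc4)sc4cc(O)ccc34)cc2)C1` alters compound 3 in one small place: methyl in place of hydrogen on a double-bonded chain carbon bound to a carbonyl carbon. This is methyl in place of hydrogen on a double-bonded chain carbon bound to a carbonyl carbon, so vinylcarbonyl becomes (1-methylethenyl)carbonyl.

For the measured compounds named here, no measured step makes this exact change, and the data give no direction for it. Going by the values given here, two steps bear on it only indirectly. The first, a 2.8-fold higher number from compound 2 to compound 3 (0.44 log units; beyond the scatter), swaps a much larger group on the same amine nitrogen in a ring, and even that step is only modest. The second, a 1.0-fold higher number from compound 1 to compound 3 (0.01 log units; within the scatter), changes what carries the vinylcarbonyl group and stays within the scatter. A single added methyl is therefore expected to shift the number by no more than the scatter, and a small step in either direction is plausible.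

The expected change is a 1.1-fold lower number from compound 3 to compound 4 (0.05 log units; within the scatter). For compound 4 the estimated value is 21000 nM, with an expected range from 9000 nM to 48000 nM.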

Compound 4, half-maximal inhibitory concentration: > 25000 nM
Compound 4: no number, only a limit; the forecaster's own chance of this, stated with the estimate: 10%; middle value at least 1.1-fold (0.07 log units) away from the limit.
By their numbers in this assay, from the lowest: compound 2; then compounds 1 and 3 (each within the scatter of the next). At a limit, above all of these: compound 4.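

In this assay compound 4 reaches only a limit of the assay and not a number: the limit of > 25000 nM in this assay, at which 1 of the 4 values shown sits.

Among the compounds shown here, the new result gives the first reading for a change at this place, methyl in place of hydrogen on a double-bonded chain carbon bound to a carbonyl carbon, but it can fix no size for that change, since an at least 1.0-fold higher number from compound 3 to compound 4 (0.02 log units; that floor lies within the scatter) and an at least 1.0-fold higher number from compound 1 to compound 4 (0.03 log units; that floor lies within the scatter) both have floors that lie within the scatter. What it does show is that the methyl brings no closing of the gap to compound 2, with an at least 2.9-fold higher number from compound 2 to compound 4 (0.47 log units; beyond the scatter), a floor beyond the scatter.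

Going by these compounds, how far past the limit the true number of compound 4 lies stays open, so the methyl could have almost no effect or a large one. Also open, on these data alone, are whether an ethyl at this same place would read any differently, and whether an amine such as dimethylamine, in place of the pyrrolidine in compound 2, would keep the lower number seen there.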